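Aryl exchange on the ring nitrogen: compound 3 to compound 4

The source may hold more compounds than are shown below. What is called first, only, known or untested is meant among the compounds shown, and "the series" means these compounds.

Measured so far:
compound 1 `COc1ccc(/C=C\C(=O)O)c(OCc2cn(-c3ccc(NC(=O)c4ccccc4)cc3)nn2)c1CC=C(C)C` — "not determined" (no result reported)
compound 2 `COc1cccc(-n2cc(COc3c(/C=C\C(=O)O)ccc(OC)c3CC=C(C)C)nn2)c1` — "not determined" (no result reported)
compound 3 `COc1ccc(/C=C\C(=O)O)c(OCc2cn(-c3cccc(C#N)c3)nn2)c1CC=C(C)C` — 45500 nM

The series shares one core and varies the aryl group on the aromatic nitrogen of the five-membered aromatic ring with 3 nitrogen. Within the data shown here, in a functional assay on PC-3 cells (Homo sapiens) for cytotoxicity, read by MTT assay, with a stated time of 24 h (a higher number here means a weaker inhibitor, a lower number a stronger inhibitor), compound 3 gives 45500 nM, the only number so far; compound 1 and compound 2 carry no result in this assay, so nothing can be said about the size or direction of any step between measured compounds, and compound 3 stands alone as a weak inhibitor.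

Compound 4 `COc1ccc(/C=C\C(=O)O)c(OCc2cn(-c3ccc(CO)cc3)nn2)c1CC=C(C)C` is the next entry. The change is 4-(hydroxymethyl)phenyl in place of 3-cyanophenyl on an aromatic nitrogen. Among the measured compounds shown here, with no measured step available to calibrate this exchange, no shift beyond the usual scatter is expected in this assay, in either direction. The value of compound 4 is estimated at 50000 nM, with a range from 20000 nM to 120000 nM; the expected step is a 1.1-fold higher number from compound 3 to compound 4 (0.04 log units; within the scatter). Compound 3 is weak at 45500 nM, and compound 4 is expected to be weak as well.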

Compound 4, half-maximal inhibitory concentration: 28300 nM
Estimate against measurement, compound 4: 1.8-fold (0.25 log units) above; low and high end bracket the measured number.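

In this assay, among these compounds, the first readable step at this position is a 1.6-fold lower number from compound 3 to compound 4 (0.21 log units; within the scatter) and it stays within the usual scatter. The position on the aromatic nitrogen therefore accepts 4-(hydroxymethyl)phenyl in place of 3-cyanophenyl without a change that can be distinguished in this read-out, even though the exchange swaps a nitrile for a hydroxymethyl group and adds 1 hydrogen-bond donor. No measurement is at hand that would account for this result.

Steps to compound 1 and compound 2 cannot be read, so this single pair is all that describes the position. Open, from the compounds shown here alone, is whether an amine, a carboxylic acid or a longer chain in place of hydroxymethyl on this phenyl ring would move the number beyond the scatter.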